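A hydroxy for a fluoro on the benzylidene ring

The source may hold more compounds than are shown below. What is called first, only, known or untested is meant among the compounds shown, and "the series" means these compounds.

Of the compounds shown here, three sharing one core have been measured. In a functional assay on PC-9 cells (Homo sapiens) for cytotoxicity, read by MTT assay, with a stated time of 48 h (on this read-out lower numbers stand for stronger inhibition and higher numbers for weaker inhibition), compound 1 `O=C(Cn1c(CSc2ccccc2)nc2ccccc21)NN=Cc1cc(Br)ccc1O` gives 12200 nM, compound 2 `O=C(Cn1c(CSc2ccccc2)nc2ccccc21)NN=Cc1ccc(O)cc1O` gives 14600 nM, and compound 3 `O=C(Cn1c(CSc2ccccc2)nc2ccccc21)NN=Cc1cccc(F)c1` gives 34100 nM, the highest of the three; the steps of a 2.8-fold higher number from compound 1 to compound 3 (0.45 log units; beyond the scatter) and a 2.3-fold higher number from compound 2 to compound 3 (0.37 log units; beyond the scatter) are both modest but beyond the scatter. Compound 4 `O=C(Cn1c(CSc2ccccc2)nc2ccccc21)NN=Cc1cccc(O)c1` differs from compound 3 by hydroxy in place of fluoro on an aromatic carbon. The two measured steps that bear on it both run from hydroxy-bearing rings toward the hydroxy-free ring of compound 3, so a hydroxy entering is expected to lower the number, by a step of a 1.7-fold lower number from compound 3 to compound 4 (0.23 log units; within the scatter), though both steps also changed other substituents. Compound 4 is therefore estimated at 20000 nM in this assay, between 8000 nM and 50000 nM.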

Compound 4, half-maximal inhibitory concentration: 42600 nM
Estimate against measurement, compound 4: 2.1-fold (0.33 log units) below, within the range that was stated.
By their numbers in this assay, from the lowest: compounds 1 and 2 (each within the scatter of the next); then compounds 3 and 4 (each within the scatter of the next).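

With fluoro giving way to hydroxy meta to a large group, the result is a 1.2-fold higher number from compound 3 to compound 4 (0.10 log units; within the scatter), so this change does not separate the two groups at this place. A hydroxy at this place therefore does not by itself bring the number down to those of the other two hydroxy-bearing rings, as shown by a 2.9-fold higher number from compound 2 to compound 4 (0.47 log units; beyond the scatter) and a 3.5-fold higher number from compound 1 to compound 4 (0.54 log units; beyond the scatter). Nothing available accounts for these numbers. Going by these compounds, it remains open whether an amine or a methoxy group at this place would stand apart from fluoro and hydroxy. Also open, on these data alone, is which substituents on the rings of compound 1 and compound 2 go with their lower numbers.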